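From Nitro to Amino on Compound 3

The compounds below may be only part of what the source reports. "The series", "measured", "known", "first", "only" and "open" are said of these compounds alone.

Measured in a functional assay on MDA-MB-468 cells (Homo sapiens) for antiproliferative activity, read by MTT assay, with a stated time of 72 h; on this read-out higher numbers stand for weaker inhibition and lower numbers for stronger inhibition:
Compound 1 `COc1cc(-c2nccn2S(=O)(=O)c2ccccc2)cc(OC)c1OC` gives > 100000 nM (a limit)
Compound 2 `COc1cc(-c2nccn2-c2ccc(C)cc2)cc(OC)c1OC` gives 400 nM
Compound 3 `COc1ccc(C(=O)Oc2cc(OC)c(OC)c(OC)c2)cc1[N+](=O)[O-]` gives 35200 nM

The value for compound 1 is a limit and not a number. Of the two true numbers, compound 3 at 35200 nM is the higher, and compound 2 at 400 nM lies lower by a gap beyond the scatter. Compound 4 `COc1ccc(C(=O)Oc2cc(OC)c(OC)c(OC)c2)cc1N` has amino in place of nitro on an aromatic carbon, ortho to a methoxy group and meta to a large group (amino in place of nitro on an aromatic carbon). Among the measured compounds shown here, no measured pair shows this change, so the expectation is loose. The estimated step of a 7.0-fold lower number from compound 3 to compound 4 (0.85 log units; beyond the scatter) is expected to be moderate and towards stronger inhibition. Compound 4 is estimated at 5000 nM (range 500 nM to 40000 nM).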

Compound 4, half-maximal inhibitory concentration: > 100000 nM
Compound 4 ended at the assay's limit; the forecaster's own chance of this, stated with the estimate: 10%; at least 20-fold (1.30 log units) between middle value and limit.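

In this assay, among the compounds shown here, amino in place of nitro on this aromatic carbon, ortho to a methoxy group, gives an at least 2.8-fold higher number from compound 3 to compound 4 (0.45 log units; beyond the scatter), so at this position nitro goes with the stronger inhibition of the two groups, which no earlier pair could show. Compound 4 gives > 100000 nM, which is a limit of the assay and not a number. The full size of the step therefore cannot be read: the limit of > 100000 nM in this assay, at which 2 of the 4 values shown sit.

As far as these compounds go, whether a hydroxyl, a fluorine or a methyl at this position would match or surpass nitro stays open. From the compounds shown here alone, whether the same change acts alike on another core also stays open.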